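Swapping the para amide for a thioether on the anilide

This account rests on a few compounds, and the source may have more. Where it says the series, first, only, none or still open, it means among the compounds named here.

Measured so far:
compound 1, `O=C(O)Cc1ccc(NC(=O)c2cn(Cc3c(F)cccc3F)c3ccc(=O)[nH]c3c2=O)cc1`: 176 nM
compound 2, `CNC(=O)c1ccc(NC(=O)c2cn(Cc3c(F)cccc3F)c3ccc(=O)[nH]c3c2=O)cc1`: 29 nM

Compound 2 gives the lowest of the two numbers in an in vitro assay on Sf21 cells for inhibition of high affinity 3',5'-cyclic-AMP phosphodiesterase 7A (Homo sapiens), read by scintillation proximity assay, with a stated time of 30 min; a higher number here means a weaker inhibitor, a lower number a stronger inhibitor; its nearest neighbour, compound 1, stands a step above it, and that step, a 6.1-fold lower number from compound 1 to compound 2 (0.78 log units; beyond the scatter), lies beyond the scatter. For the measured compounds named here, the only change from compound 2 to compound 3, `CSc1ccc(NC(=O)c2cn(Cc3c(F)cccc3F)c3ccc(=O)[nH]c3c2=O)cc1`, is methylsulfanyl in place of methylcarbamoyl on an aromatic carbon. Going by the values given here, the one measured step that bears on this position shows that what sits on that aromatic carbon matters, yet neither measured group resembles methylsulfanyl, which carries no hydrogen-bond donor and no carbonyl. A weaker number than compound 2 is therefore expected for compound 3, and the step is estimated as a 4.1-fold higher number from compound 2 to compound 3 (0.62 log units; beyond the scatter). In this assay, compound 3 is estimated at 120 nM, within a range from 35 nM to 450 nM.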

Compound 3, half-maximal inhibitory concentration: 86 nM
For compound 3 the middle estimate is 1.4-fold (0.14 log units) above the measured one; measured number inside the range.
By their numbers in this assay, from the lowest: compound 2; then compound 3; then compound 1.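

Methylsulfanyl on this aromatic carbon, para to a large group, does not match methylcarbamoyl (a 3.0-fold higher number from compound 2 to compound 3 (0.47 log units; beyond the scatter)) in this assay, but it does improve on carboxymethyl (a 2.0-fold lower number from compound 1 to compound 3 (0.31 log units; beyond the scatter)). The position therefore tolerates a group with 0 hydrogen-bond donors and no carbonyl, and such a group can still give a lower number than compound 1, although compound 2 remains the lowest of the three. Nothing measured here explains this ordering. The compounds shown leave open whether the advantage of compound 2 depends on the amide hydrogen or on the carbonyl, which a dimethylcarbamoyl group could help to separate. They also leave open how a carboxylic acid on this same aromatic carbon, a methoxy group or a longer ethylsulfanyl chain would compare.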